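Shortening the Ring Amide Substituent Toward Bare Nitrogen

The compounds below may be only part of what the source reports. "The series", "measured", "known", "first", "only" and "open" are said of these compounds alone.

Compound 3 `CCN1C(=O)C2(C(C#N)=C(N)Oc3cc4oc(-c5ccccc5)cc(=O)c4c(O)c32)c2cc(C)ccc21` carries an ethyl on the ring amide nitrogen of the shared core. In a functional assay on A549 cells (Homo sapiens) for antiproliferative activity, read by MTT assay, with a stated time of 48 h (a lower number here means a stronger inhibitor, a higher number a weaker inhibitor), compound 3 gives only a limit, > 50000 nM. Compound 2 `N#CC1=C(N)Oc2cc3oc(-c4ccccc4)cc(=O)c3c(O)c2C12C(=O)N(c1ccccc1)c1ccccc12` also reaches only a limit: in this assay compound 2 gives > 50000 nM. Going by the values given here, compound 1 `Cc1ccc2c(c1)C1(C(=O)N2C)C(C#N)=C(N)Oc2cc3oc(-c4ccccc4)cc(=O)c3c(O)c21` is the one member with a measured number; in this assay compound 1 gives 7060 nM. Compound 3 thus sits at the limit of > 50000 nM in this assay, at which 2 of the 3 values shown sit, the weak end of what was measured. Compound 4 `Cc1ccc2c(c1)C1(C(=O)N2)C(C#N)=C(N)Oc2cc3oc(-c4ccccc4)cc(=O)c3c(O)c21` differs from compound 3 by hydrogen in place of ethyl on an amide-type nitrogen in a ring. Among the compounds with values here, the one relevant step, an at least 7.0-fold higher number from compound 1 to compound 3 (0.85 log units; beyond the scatter), shows that lengthening methyl to ethyl cost potency, so removing the ethyl entirely may reverse that, though no measured step covers this change. Compound 4 is therefore expected near 10000 nM, within 2000 nM to 50000 nM, a step of an at least 5.0-fold lower number from compound 3 to compound 4 (0.69 log units; beyond the scatter).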

Compound 4, half-maximal inhibitory concentration: > 50000 nM
Compound 4: no number, only a limit (the forecaster's own chance of this, stated with the estimate: 35%); middle value at least 5.0-fold (0.69 log units) from the limit.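

In this assay compound 4 also reaches only a limit, > 50000 nM. Hydrogen in place of methyl on this amide-type nitrogen gives an at least 7.0-fold higher number from compound 1 to compound 4 (0.85 log units; beyond the scatter), so removing the group does not help, and the methyl of compound 1 now stands out against both the smaller hydrogen and the longer ethyl. The step between compound 3 and compound 4 cannot be read, and the set now sits mostly at one value: the limit of > 50000 nM in this assay, at which 3 of the 4 values shown sit.

The compounds shown leave open whether a cyclopropyl or a hydroxyethyl group on this nitrogen would give a measured number, as the methyl of compound 1 does.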